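The source may report more compounds than this note shows. Statements on the series, on what has been measured and on what is new or still open speak of the compounds shown alone.

Measured so far in a physicochemical assay for lipophilicity, at pH 7.4; a higher number here means a more lipophilic compound, a lower number a more polar compound:
Compound 1 `Cc1cc(C(=O)O)nn1Cc1cc(Br)ccc1OCc1ccccc1` gives 1.2.
Compound 2 `Cc1cc(C(=O)NCc2ccccn2)nn1Cc1cc(Cl)ccc1OCc1ccccc1` gives only a limit of this assay, > 3.7, not a number; this is the limit of > 3.7 in this assay, at which 1 of the 3 values shown sits.
Compound 3 `Cc1cc(C(=O)NN2CCOCC2)nn1Cc1cc(Cl)ccc1OCC(C)C` gives 3.1.

As far as these compounds go, compound 2 therefore stands at the upper limit of this assay, and where it lies beyond that is unknown. Among the compounds with values here, no pair of measured compounds differs in a single place, so no measured step is available.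

Compound 4 `Cc1cc(NC(=O)C2CCOCC2)nn1Cc1cc(Cl)ccc1OCc1ccccc1` differs from compound 2 in one place: ((oxan-4-yl)carbonyl)amino in place of ((pyridin-2-yl)methyl)carbamoyl on an aromatic carbon.

The distribution coefficient of compound 4 is expected to move downward from the limit, with a number at least 0.80 log units lower from compound 2 to compound 4 (beyond the scatter) as the estimated step, beyond the usual scatter. Compound 4 is estimated at 2.9, with a range from 2.3 to 3.5.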

Compound 4, distribution coefficient: > 3.7
Compound 4 was reported as a limit; the forecaster's own chance of this, stated with the estimate: 10%; middle value at least 0.80 log units away from the limit.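

In this assay, within the data shown here, compound 4 gives > 3.7, a limit and not a number, and compound 2 also stands at that limit, so no step between them can be read. The compounds shown leave open whether ((oxan-4-yl)carbonyl)amino in place of ((pyridin-2-yl)methyl)carbamoyl changes the distribution coefficient at all.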